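Positional isomer of the aryl methyl in the shared core

The source may report more compounds than this note shows. Statements on the series, on what has been measured and on what is new or still open speak of the compounds shown alone.

Going by the values given here, of the two compounds measured so far in a functional assay on CHO cells for antagonist activity at adenosine receptor A1 (Homo sapiens), read by cAMP accumulation, with a stated time of 10 min (on this read-out lower numbers stand for stronger inhibition and higher numbers for weaker inhibition), compound 2 `Cc1ccc(-c2nc3c(NC4CCCC4)ncnc3n2C)cc1` gives 61 nM. Among the compounds with values here, compound 1 `Cn1c(-c2ccc(F)cc2)nc2c(NC3CCCC3)ncnc21` gives 32 nM, and the two numbers lie within the scatter of each other: the only measured step, a 1.9-fold higher number from compound 1 to compound 2 (0.28 log units; within the scatter), a methyl in place of fluoro on an aromatic carbon, did not move the read-out beyond the scatter. Compound 3 `Cc1cccc(-c2nc3c(NC4CCCC4)ncnc3n2C)c1` has not been measured. It differs from compound 2 by 3-methylphenyl in place of 4-methylphenyl on an aromatic carbon, a 3-methylphenyl in place of a 4-methylphenyl on an aromatic carbon. That one step bears on it only loosely, since it swapped the substituent rather than its position, but it shows that altering this group left the number essentially unchanged. A step of no more than scatter size, in either direction, is therefore expected; the expected step is a 1.0-fold lower number from compound 2 to compound 3 (0.01 log units; within the scatter). Compound 3 is estimated at 60 nM, with a range from 25 nM to 150 nM.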

Compound 3, half-maximal inhibitory concentration: 43 nM
Estimate against measurement, compound 3: 1.4-fold (0.14 log units) above; the range from low to high includes it.
By their numbers in this assay, from the lowest: compounds 1, 3 and 2 (each within the scatter of the next).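

Setting the methyl as 3-methylphenyl in place of 4-methylphenyl gives a 1.4-fold lower number from compound 2 to compound 3 (0.15 log units; within the scatter) in this assay; this is the first direct reading of the methyl's place on the aryl group, and this assay does not tell the two isomers apart. The step of a 1.3-fold higher number from compound 1 to compound 3 (0.13 log units; within the scatter) also stays within the scatter, so compound 1, compound 2 and compound 3 all lie within the scatter of one another, whether the aryl group is 4-fluorophenyl, 4-methylphenyl or 3-methylphenyl. No supporting data accompany these numbers to account for this flat picture.

Each aryl group shown carries a single methyl or fluoro, so the reading for an amine or a carboxylic acid on that aryl group remains open. Also open, on these data alone, is the effect of a longer chain in place of the methyl group on the shared core.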